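Butyl in place of phenyl on a carbonyl carbon

The source may report more compounds than this note shows. Statements on the series, on what has been measured and on what is new or still open speak of the compounds shown alone.

In an ADME assay on HepG2 2.2.15 cells (Homo sapiens) for cytotoxicity, read by MTT assay (a higher number here means that more compound is tolerated, a lower number that less compound is tolerated), compound 1 (`C=C1CC[C@@H]2[C@](C)(COC(=O)c3ccco3)[C@H](O)CC[C@@]2(C)[C@@H]1C/C=C1\C=COC1=O`) gives > 2150000 nM as a limit of the assay, not a number. Among the measured compounds shown here, compound 2 (`C=C1CC[C@@H]2[C@](C)(COC(=O)c3cccs3)[C@H](O)CC[C@@]2(C)[C@@H]1C/C=C1\C=COC1=O`) gives 2470000 nM and compound 3 (`C=C1CC[C@@H]2[C@](C)(COC(=O)c3ccccc3)[C@H](O)CC[C@@]2(C)[C@@H]1C/C=C1\C=COC1=O`) gives 82000 nM as the lowest number so far. Compound 4 (`C=C1CC[C@@H]2[C@](C)(COC(=O)CCCC)[C@H](O)CC[C@@]2(C)[C@@H]1C/C=C1\C=COC1=O`) differs from compound 3 by one change (butyl in place of phenyl on a carbonyl carbon): butyl in place of phenyl on a carbonyl carbon. For the measured compounds named here, two measured steps bear on it, both large and both ending on phenyl (an at least 26-fold lower number from compound 1 to compound 3 (1.41 log units; beyond the scatter) and a 30-fold lower number from compound 2 to compound 3 (1.48 log units; beyond the scatter)), so a higher number is expected in this assay once phenyl leaves. Butyl itself is untested, so only part of that gap is expected back. The expected step is moderate (a 3.0-fold higher number from compound 3 to compound 4 (0.48 log units; beyond the scatter)). Compound 4 is estimated at 250000 nM (range 60000 nM to 1500000 nM).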

Compound 4, half-maximal cytotoxic concentration: 225000 nM
Estimate against measurement, compound 4: 1.1-fold (0.05 log units) above; the range from low to high includes it.
By their numbers in this assay, from the lowest: compound 3; then compound 4; then compound 2.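

In this assay, swapping phenyl for butyl on this carbonyl carbon gives a 2.7-fold higher number from compound 3 to compound 4 (0.44 log units; beyond the scatter), so an open chain recovers only part of the gap. Butyl still falls well short of the two heteroaromatic groups, with an 11-fold lower number from compound 2 to compound 4 (1.04 log units; beyond the scatter) and an at least 9.5-fold lower number from compound 1 to compound 4 (0.98 log units; beyond the scatter), so losing the phenyl ring does not by itself restore the high numbers. The furan-2-yl step starts from a limit of the assay, not a number: the limit of > 2150000 nM in this assay, at which 1 of the 4 values shown sits.

Going by these compounds, whether a longer chain or a branched chain would stay near butyl remains open. So does where a pyridin-3-yl ring would fall relative to phenyl and thiophen-2-yl.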